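This account rests on a few compounds, and the source may have more. Where it says the series, first, only, none or still open, it means among the compounds named here.

Working notes on the series, measured in a functional assay on MCF7 cells (Homo sapiens) for inhibition, read by MTT assay, with a stated time of 48 h, tested at 10 uM; a higher number here means more inhibition of growth at the concentration tested, a lower number less inhibition of growth:

- compound 1 `Cc1cc(=O)c2c(O)c(CN3CCC(N4CCCCC4)CC3)c(O)c([C@H]3CCN(C)C[C@H]3O)c2o1`: 25%
- compound 2 `CCOC(=O)N1CCN(Cc2c(O)c([C@H]3CCN(C)C[C@H]3O)c3oc(C)cc(=O)c3c2O)CC1`: 31%
- compound 3 `Cc1oc2c([C@H]3CCN(C)C[C@H]3O)c(O)cc(O)c2c(=O)c1C(O)c1cccc(Cl)c1`: 5%

Compound 3 stands lowest of the three, and the gaps up to compound 1 and compound 2 both lie beyond the scatter. Compound 1 and compound 2 lie within the scatter of each other, and neither can be ranked over the other on these numbers.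

The next compound to be tested in this assay is compound 4 `Cc1oc2c([C@H]3CCN(C)C[C@H]3O)c(O)cc(O)c2c(=O)c1C(O)c1ccc(F)c(Br)c1`. It keeps the shared core of compound 3 and changes only the aryl group: 3-bromo-4-fluorophenyl in place of 3-chlorophenyl on a saturated chain carbon bound to an aromatic carbon and an oxygen on a saturated carbon. The hydroxyl-bearing chain carbon stays in place, and 3-bromo-4-fluorophenyl takes the place of 3-chlorophenyl on it.

For the measured compounds named here, no pair of measured compounds differs in one place only, so the data give no measured size for a change of this kind. Compound 1 and compound 2 carry other groups on the core and offer no direct guide to an exchange of aryl groups. Going by the values given here, the only anchor is compound 3 at 5%. The expected step of a number 3 percentage points higher from compound 3 to compound 4 (within the scatter) is small, slightly upward and within the scatter. For compound 4 the estimated value is 8%, with an expected range of 0% to 20%.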

Compound 4, percent growth inhibition at one concentration: 14%
For compound 4 the middle estimate is 6 percentage points below the measured one; the range from low to high includes it.
By their numbers in this assay, from the lowest: compounds 3 and 4 (each within the scatter of the next); then compounds 1 and 2 (each within the scatter of the next).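

In this assay, 3-bromo-4-fluorophenyl in place of 3-chlorophenyl on a saturated chain carbon bound to an aromatic carbon and an oxygen on a saturated carbon gives a number 9 percentage points higher from compound 3 to compound 4 (within the scatter), the first measured size for any single change in the series. On these numbers the two aryl groups cannot be told apart at this place, so the exchange of the chlorine for a bromine together with the added fluorine leaves no readable shift in growth inhibition at the concentration tested. Nothing measured here bears on why the step has this size.

Steps from compound 1 or compound 2 to compound 3 or compound 4 cannot be read, since those compounds differ in more than one place. With only two halogenated phenyl groups shown at this place, it stays open how far the read-out would move with an unsubstituted phenyl, with an amine or a carboxylic acid on the aryl ring, or with a longer chain in place of the aryl group.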